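This account rests on a few compounds, and the source may have more. Where it says the series, first, only, none or still open, it means among the compounds named here.

Compound 1 `COc1cc(/C=C/c2ccc(O)cc2)c(OC)cc1/C=C/c1ccc(O)cc1` gives 5 in a physicochemical assay for lipophilicity, read by HPLC; on this read-out higher numbers stand for higher lipophilicity and lower numbers for lower lipophilicity.
Compound 2 `COc1cc(/C=C/c2ccc(CO)cc2)ccc1/C=C/c1ccc(CO)cc1` gives 4.99 in this assay.
Compound 3 `COc1cc(/C=C/c2ccc(C(F)(F)C(F)F)cc2)ccc1/C=C/c1ccc(C(F)(F)C(F)F)cc1` gives > 7 in this assay.

For compound 3 only a limit is known: its reading is the limit of > 7 in this assay, at which 1 of the 3 values shown sits, so no number stands for it in this assay. Compound 4 `Oc1cc(/C=C/c2ccc(C(F)(F)C(F)F)cc2)ccc1/C=C/c1ccc(C(F)(F)C(F)F)cc1` differs from compound 3 in one place: hydrogen in place of methyl on an oxygen on an aromatic ring, that is, methoxy to hydroxy. No step between measured compounds covers this change, so it has no measured counterpart among these three. In this assay compound 4 is expected to come out lower, by a step somewhat beyond the usual scatter, a number at least 0.20 log units lower from compound 3 to compound 4 (that floor lies within the scatter). The estimate for compound 4 in this assay is 6.8, with a range from 6.2 to 7.4, and a fair chance remains that only a limit is reported again.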

Compound 4, partition coefficient: > 7
Compound 4: only a limit was reported; the forecaster's own chance of this, stated with the estimate: 45%; middle value at least 0.20 log units away from the limit.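

Among these compounds, compound 3 and compound 4 both give only a limit in this assay and no step between them can be read: the limit of > 7 in this assay, at which 2 of the 4 values shown sit. What the change from methoxy to hydroxy does in this assay remains open among the compounds shown.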